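Furan-3-yl to 2,6-Difluoropyridin-4-yl: an Efficacy Expectation

The source may hold more compounds than are shown below. What is called first, only, known or untested is meant among the compounds shown, and "the series" means these compounds.

Compound 3 `O=C(O)Cc1sc(C(c2ccc(F)cc2)c2ccc(F)cc2)nc1-c1ccoc1` stands level with compound 1 `N#Cc1cc(-c2nc(C(c3ccc(F)cc3)c3ccc(F)cc3)sc2CC(=O)O)ccc1F` and compound 2 `O=C(O)Cc1sc(C(c2ccc(F)cc2)c2ccc(F)cc2)nc1-c1ccco1` in an in vitro functional assay on HEK285-7 cells for antagonist activity at prostaglandin D2 receptor 2 (Homo sapiens), read by BRET and beta-arrestin recruitment; a lower number here means a smaller maximal response, a higher number a larger maximal response: compound 1 gives 80%, compound 2 gives 80%, and compound 3 gives 80%. The measured steps are no change at the digits printed from compound 1 to compound 2 (within the scatter), no change at the digits printed from compound 1 to compound 3 (within the scatter) and no change at the digits printed from compound 2 to compound 3 (within the scatter), each within the scatter. Compound 4 `O=C(O)Cc1sc(C(c2ccc(F)cc2)c2ccc(F)cc2)nc1-c1cc(F)nc(F)c1` differs from compound 3 by 2,6-difluoropyridin-4-yl in place of furan-3-yl on an aromatic carbon. All three measured steps exchange the group on this same aromatic carbon, and none of them moved the maximal response beyond the scatter, so a step of about zero, with no clear direction, is expected here, no change at the digits printed from compound 3 to compound 4 (within the scatter). For compound 4 the estimated maximal response in this assay is 80%, within 66% to 92%.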

Compound 4, largest response reached (reported as efficacy), in percent of the reference or control that the assay uses: 80%
Compound 4: middle estimate and measured number agree at the digits printed, within the range that was stated.
By their numbers in this assay, from the lowest: compounds 1, 2, 3 and 4 (each within the scatter of the next).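

With 2,6-difluoropyridin-4-yl, a six-membered aromatic ring with 1 hetero atom now stands on this aromatic carbon, and this assay shows no change at the digits printed from compound 3 to compound 4 (within the scatter) and no change at the digits printed from compound 2 to compound 4 (within the scatter) and also no change at the digits printed from compound 1 to compound 4 (within the scatter) for this change. The maximal response therefore stays within the scatter across this wider set of aromatic rings, now including a pyridine with two fluorines. On these data alone, whether a saturated piperidine ring or an open alkyl chain on this carbon would move the maximal response remains open. Nothing available here gives a reason for this flat result.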